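Swapping the Aryl Group on a Carbamate Chain

The compounds below may be only part of what the source reports. "The series", "measured", "known", "first", "only" and "open" are said of these compounds alone.

In an assay on CHO cells for displacement of a labelled ligand from muscarinic acetylcholine receptor M5 (Homo sapiens), read by scintillation counting, with a stated time of 2 h (on this read-out higher numbers stand for weaker inhibition and lower numbers for stronger inhibition), three compounds have been measured so far:

Compound 1 `COc1ccc(CCCOC(=O)N(c2ccccc2)C2CN3CCC2CC3)cc1` gives 640 nM.
Compound 2 `COc1ccc(COC(=O)N(c2ccccc2)C2CN3CCC2CC3)cc1OC` gives 550 nM.
Compound 3 `O=C(OCc1ccccc1)N(c1ccccc1)C1CN2CCC1CC2` gives 150 nM.

Compound 1 stands at the highest of the three numbers. Compound 2 lies within the scatter of it, so no order between the two can be read. Compound 3 sits beyond the scatter, at a lower number than compound 1.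

Compound 4 `O=C(OCCCc1ccc(Cl)c(Cl)c1)N(c1ccccc1)C1CN2CCC1CC2` is the untested analogue; it differs from compound 1 by 3,4-dichlorophenyl in place of 4-methoxyphenyl on a saturated chain carbon, three bonds along the chain from an oxygen next to a carbonyl group. Among the compounds with values here, no pair among the measured compounds isolates this change, so the size of the step is uncertain. The account expects a modest move toward a lower number in this assay, a 2.1-fold lower number from compound 1 to compound 4 (0.33 log units; beyond the scatter), and the estimate for compound 4 is 300 nM, in a range from 80 nM to 1200 nM.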

Compound 4, inhibition constant: 130 nM
Beside the measured number, compound 4's estimate is 2.3-fold (0.36 log units) above it, within the range that was stated.
By their numbers in this assay, from the lowest: compounds 4 and 3 (each within the scatter of the next); then compounds 2 and 1 (each within the scatter of the next).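

In this assay, within the data shown here, 3,4-dichlorophenyl in place of 4-methoxyphenyl on this saturated chain carbon gives a 4.9-fold lower number from compound 1 to compound 4 (0.69 log units; beyond the scatter) and is the first step here that isolates one change. It shows that the aryl group at this place alone can move the number beyond the scatter. Nothing available accounts for the step.

The compounds shown leave open whether a single chlorine, as in 4-chlorophenyl, would give a similar step. From the compounds shown here alone, how a pyridine ring or an amine at this place would read also remains open.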